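The source may hold more compounds than are shown below. What is called first, only, known or untested is meant among the compounds shown, and "the series" means these compounds.

Compound 1 `c1ccc(Sc2nn3cc(-c4cc5ccccc5o4)nc3s2)cc1` gives 1900 nM in a functional assay on HEK293 cells for antagonist activity at proteinase-activated receptor 4 (Homo sapiens), read by FLIPR and calcium flux, with a stated time of 30 min; a lower number here means a stronger inhibitor, a higher number a weaker inhibitor.
Compound 2 `COc1cc(OCc2cccc(COc3ccccc3)c2)c2cc(-c3cn4nc(OC)sc4n3)oc2c1` gives 3.2 nM in this assay.

Of the two numbers measured, compound 2 has the lower one, and compound 1 stands far above it, a gap well beyond the ordinary scatter of repeated runs. The two compounds differ in many places at once, so nothing about the effect of any single change can be drawn from that pair. Compound 3 `COc1cc(OCc2cccc(C#N)c2)c2cc(-c3cn4nc(OC)sc4n3)oc2c1` is the untested member. It keeps the whole of compound 2 except at one place: cyano in place of phenoxymethyl on an aromatic carbon. In plain words, cyano in place of phenoxymethyl on an aromatic carbon. Within the data shown here, no measured pair isolates this kind of swap, so the expectation rests only on the fact that a larger group gives way to a much smaller one while the rest of compound 2, which gives the lowest number seen, stays intact. Compound 3 is expected to come out weaker, by a step of a 9.4-fold higher number from compound 2 to compound 3 (0.97 log units; beyond the scatter) that probably exceeds the scatter. The estimate for compound 3 is 30 nM, with a range from 5 nM to 300 nM.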

Compound 3, half-maximal inhibitory concentration: 0.98 nM
Compound 3: middle estimate off by 31-fold (1.49 log units), on the high side, and the stated range ends above it.
By their numbers in this assay, from the lowest: compound 3; then compound 2; then compound 1.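

In this assay, cyano in place of phenoxymethyl on this aromatic carbon gives a 3.3-fold lower number from compound 2 to compound 3 (0.51 log units; beyond the scatter), so the number falls even though a group of 8 heavy atoms that carries a six-membered aromatic ring gives way to one of 2 heavy atoms with no ring. Within this pair, then, the phenoxymethyl group and its outer ring are not needed for a low number, and a much smaller group at this position on the ring does at least as well on the otherwise unchanged compound. No measurement at hand explains why the smaller group gives the lower number.

The compounds shown leave open whether cyano itself matters or whether removing phenoxymethyl is what counts, since only this one pair speaks to the position; a bare hydrogen, a methyl or a chlorine at the same carbon would help separate those two readings. As far as these compounds go, it also remains open how an amine or a carboxylic acid would fare there, and whether the same swap would act alike on a different core, such as that of compound 1.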